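Pyridin-2-yl to a fused bicyclic amine: expectation for compound 4

This account rests on a few compounds, and the source may have more. Where it says the series, first, only, none or still open, it means among the compounds named here.

Compound 1, `C[C@@H](Cn1ccc(-c2ccc(C#N)c(Cl)c2)n1)NC(=O)c1ccccc1`, in an ADME assay on PC-3 cells (Homo sapiens) for cytotoxicity, read by CCK-8 assay, with a stated time of 6 days (a lower number here means a stronger inhibitor, a higher number a weaker inhibitor), gives > 30000 nM, a limit of the assay.
Compound 2, `C[C@@H](Cn1ccc(-c2ccc(C#N)c(Cl)c2)n1)NC(=O)c1ccccc1F`, in this assay gives > 30000 nM, also a limit of the assay.
Compound 3, `C[C@@H](Cn1ccc(-c2ccc(C#N)c(Cl)c2)n1)Nc1ccccn1`, in this assay gives "not determined" (no result reported), that is, no reported result.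

Going by the values given here, the only step among the measured compounds, a step that the two limits leave unreadable from compound 1 to compound 2, is fluoro in place of hydrogen on an aromatic carbon, and its size cannot be read, because of the limit of > 30000 nM in this assay, at which 2 of the 3 values shown sit. Compound 3 therefore stands nowhere on the numbers shown: it was not determined in this assay, and its two amide neighbours give only limits.

Compound 4, `C[C@@H](Cn1ccc(-c2ccc(C#N)c(Cl)c2)n1)Nc1ncnc2nc[nH]c12`, differs from compound 3 by a group of 9 heavy atoms (5 carbon, 4 nitrogen; one five-membered aromatic ring with 2 hetero atoms, one six-membered aromatic ring with 2 hetero atoms) in place of a group of 6 heavy atoms (5 carbon, 1 nitrogen; one six-membered aromatic ring with 1 hetero atom), on an amine nitrogen, that is, a group of 9 heavy atoms in place of a group of 6 heavy atoms on an amine nitrogen whose other neighbour is a saturated chain carbon. Among the compounds with values here, no measured step bears on this change, and compound 3 itself carries no number, so no direction beyond the scatter can be expected from the data. Given that both measured compounds sit at a limit in this assay, compound 4 is expected to give about 40000 nM, within 12000 nM to 120000 nM, most likely again as a limit.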

Compound 4, half-maximal inhibitory concentration: 14100 nM
Beside the measured number, compound 4's estimate is 2.8-fold (0.45 log units) above it, and the stated range covers the measured number.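

In this assay compound 4 gives 14100 nM, the only actual number among the compounds shown, so a group on this amine nitrogen can bring the read-out inside the range of the assay. Set against the two amide compounds, the fused two-ring group carrying four nitrogens gives an at least 2.1-fold lower number from compound 1 to compound 4 (0.32 log units; beyond the scatter) and an at least 2.1-fold lower number from compound 2 to compound 4 (0.32 log units; beyond the scatter). Both steps are minimum sizes only, because the amide compounds stand at a limit: the limit of > 30000 nM in this assay, at which 2 of the 4 values shown sit.

Compound 3 has no reported result, so the change from pyridin-2-yl to the fused group cannot be sized, and the step between the two amide compounds cannot be read either. As far as these compounds go, whether a single pyrimidinyl ring on this amine nitrogen would give a number like that of compound 4 remains open.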